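A few compounds are considered here, and "the series" means these few. Any claim that something is new, unique, unknown or untested is made for them only; others in the source may bear on it.

Of the compounds shown here, three built on one shared core have been measured in an assay on HEK293 cells for inhibition of Voltage-dependent T-type calcium channel subunit alpha-1G (Homo sapiens), read by patch clamp; on this read-out higher numbers stand for weaker inhibition and lower numbers for stronger inhibition. Compound 1 `CCCc1nc(-c2ccccc2)c(CNCCN2CCN(c3cccc(C(F)(F)F)c3)CC2)o1` gives 1940 nM in this assay. Of the three numbers, compound 1 stands second highest. Its nearest neighbour is compound 2 `CCCc1nc(-c2ccccc2)c(CNCCCN2CCN(c3cccc(C(F)(F)F)c3)CC2)o1`, which gives 650 nM in this assay, a lower number by a step beyond the scatter. Furthest from compound 1 is compound 3 `CCCc1nc(-c2ccccc2)c(CNCCN2CCN(C(c3ccccc3)c3ccccc3)CC2)o1`, which gives 7470 nM in this assay, a higher number, again beyond the scatter.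

Compound 4 `CCCc1nc(-c2ccccc2)c(CNCCN2CCN(c3ccc(OC)cc3)CC2)o1` has not been measured. It differs from compound 1 in one place: 4-methoxyphenyl in place of 3-(trifluoromethyl)phenyl on an amine nitrogen in a ring. Going by the values given here, no measured pair shows this same exchange, so the size of its step cannot be read off and can only be expected. The measured compounds do show that the group on this ring nitrogen matters, since compound 3 with a different group there gives 7470 nM, whereas compound 1 gives 1940 nM. The exchange of a trifluoromethyl-bearing ring for a methoxy-bearing one is expected to weaken inhibition only modestly, perhaps barely beyond the scatter, so the expected step is a 1.8-fold higher number from compound 1 to compound 4 (0.26 log units; within the scatter). Compound 4 is therefore estimated at 3500 nM, within a range from 1200 nM to 10000 nM.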

Compound 4, half-maximal inhibitory concentration: 9200 nM
Estimate against measurement, compound 4: 2.6-fold (0.42 log units) below, and the stated range covers the measured number.
By their numbers in this assay, from the lowest: compound 2; then compound 1; then compounds 3 and 4 (each within the scatter of the next).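

In this assay, exchanging 3-(trifluoromethyl)phenyl for 4-methoxyphenyl on the ring nitrogen gives a 4.7-fold higher number from compound 1 to compound 4 (0.68 log units; beyond the scatter), so this position responds strongly even when the group keeps one six-membered aromatic ring of carbon only. The earlier compounds shown here showed sensitivity here only with compound 3, whose group on this nitrogen is built differently; now compound 3 at 7470 nM and compound 4 at 9200 nM stand within the scatter of each other, which means that two quite different groups on this nitrogen can land at the same level. Nothing measured here explains why the step is this large.

The exchange alters both the substituent and its place on the ring, so the step cannot be split between the two: 3-methoxyphenyl, 4-(trifluoromethyl)phenyl or plain phenyl on this nitrogen would tell them apart. From the compounds shown here alone, it also remains open whether 4-methoxyphenyl would cost as much on the longer chain of compound 2, which gives 650 nM with 3-(trifluoromethyl)phenyl in place.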